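Furan to isoquinoline on an octadecyl threonine amide

The source may hold more compounds than are shown below. What is called first, only, known or untested is meant among the compounds shown, and "the series" means these compounds.

Compound 1, `CCCCCCCCCCCCCCCCCCNC(=O)[C@@H](N)[C@@H](C)O`: 21400 nM in a functional assay on SW-620 cells (Homo sapiens) for cytotoxicity, read by MTT assay, with a stated time of 48 h; on this read-out lower numbers stand for stronger inhibition and higher numbers for weaker inhibition
Compound 2, `CCCCCCCCNC(=O)[C@@H](NC(=O)c1nccc2ccccc12)[C@@H](C)O`: 67800 nM in this assay
Compound 3, `CCCCCCCCCCCCCCCCCCNC(=O)[C@@H](NC(=O)c1ccco1)[C@@H](C)O`: reaches only the assay limit, > 200000 nM

Compound 3 thus stands at the limit of this assay, without a number of its own. Going by the values given here, the one measured step that reaches it, an at least 9.3-fold higher number from compound 1 to compound 3 (0.97 log units; beyond the scatter), runs up to the limit of > 200000 nM in this assay, at which 1 of the 3 values shown sits. Compound 4, `CCCCCCCCCCCCCCCCCCNC(=O)[C@@H](NC(=O)c1nccc2ccccc12)[C@@H](C)O`, differs from compound 3 by isoquinolin-1-yl in place of furan-2-yl on a carbonyl carbon. Among the compounds with values here, no measured pair isolates this change; compound 2, which carries the same (isoquinolin-1-yl)carbonyl group, gives 67800 nM in this assay. On that basis compound 4 is expected to return to a measurable number, so the estimated step of an at least 2.0-fold lower number from compound 3 to compound 4 (0.30 log units; that floor lies within the scatter) points toward a lower value. Compound 4 is estimated at 100000 nM, within 30000 nM to 300000 nM.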

Compound 4, half-maximal inhibitory concentration: 136000 nM
For compound 4 the middle estimate is 1.4-fold (0.13 log units) below the measured one; the range from low to high includes it.
By their numbers in this assay, from the lowest: compound 1; then compounds 2 and 4 (each within the scatter of the next). At a limit, above all of these: compound 3.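

Isoquinolin-1-yl in place of furan-2-yl gives compound 4 a measurable number, but the step of an at least 1.4-fold lower number from compound 3 to compound 4 (0.16 log units; that floor lies within the scatter) is only a floor, and compound 3 remains a limit: the limit of > 200000 nM in this assay, at which 1 of the 4 values shown sits.

The acyl group still carries a cost on the amine nitrogen, with a 6.4-fold higher number from compound 1 to compound 4 (0.80 log units; beyond the scatter). Adding decyl to the chain gives no change that can be told apart, with a 2.0-fold higher number from compound 2 to compound 4 (0.30 log units; within the scatter).

The compounds shown leave open how a benzoyl group on the same nitrogen would read. They also leave open how a chain shorter than octyl would read.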